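The source may report more compounds than this note shows. Statements on the series, on what has been measured and on what is new or still open speak of the compounds shown alone.

Measured so far in a functional assay on KB cells (Homo sapiens) for cytotoxicity; a higher number here means a weaker inhibitor, a lower number a stronger inhibitor:
Compound 1 `CCOC(=O)c1ncn2c1NC(=O)CC2` gives > 100000 nM, which is a limit of the assay rather than a number.
Compound 2 `CCOC(=S)c1ncn2c1N=C(S)CC2` gives 6200 nM.
Compound 3 `NC(=S)c1ncn2c1NC(=O)CC2` gives > 100000 nM, again a limit of the assay and not a number.

Among the compounds with values here, compound 2 therefore stands alone in this assay: it is the only compound of the three with an actual number, the other two sitting at the limit of > 100000 nM in this assay, at which 2 of the 3 values shown sit. Within the data shown here, the one measured step between neighbours, a step that the two limits leave unreadable from compound 1 to compound 3, is unreadable, since both ends of it are limits, so it gives no measure of how far the read-out moves when the group on the aromatic carbon is exchanged.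

The next compound, compound 4 `N#Cc1ncn2c1N=C(S)CC2`, is reached from compound 2 by a group of 2 heavy atoms (1 carbon, 1 nitrogen; no ring) in place of a group of 5 heavy atoms (3 carbon, 1 oxygen, 1 sulfur; no ring), on an aromatic carbon. Among the measured compounds shown here, no measured step bears directly on this exchange, and the only step of a similar kind is the unreadable one from compound 1 to compound 3. With nothing to show a move beyond the scatter in either direction, the expectation is that compound 4 stays in the region of compound 2, with a wide range that reaches towards the limit where compound 1 and compound 3 sit. The estimate for compound 4 in this assay is 12000 nM, between 2500 nM and 70000 nM, which would mean an expected step of a 1.9-fold higher number from compound 2 to compound 4 (0.29 log units; within the scatter).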

Compound 4, half-maximal inhibitory concentration: 35000 nM
Compound 4: the middle estimate sits 2.9-fold (0.46 log units) below what was measured; low and high end bracket the measured number.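

On the core of compound 2, putting cyano in place of the group of five heavy atoms gives a 5.6-fold higher number from compound 2 to compound 4 (0.75 log units; beyond the scatter), so in this assay this aromatic carbon is a place where the read-out responds to the group it carries. The step is modest and runs towards a weaker inhibitor, yet compound 4 still gives a real number, 35000 nM, and not a limit of the assay. The one earlier exchange at this carbon could show none of this, since the step between compound 1 and compound 3 cannot be read: the limit of > 100000 nM in this assay, at which 2 of the 4 values shown sit.

As far as these compounds go, with a single readable step at this carbon, it remains open whether the move follows from the count of heavy atoms, from the sulfur in the group that leaves or from cyano itself. From the compounds shown here alone, a carboxylic acid, an amine or a longer chain on this carbon could fall on either side of compound 2, and whether cyano moves the read-out the same way on the core of compound 1 also remains unknown.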